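The source may hold more compounds than are shown below. What is called first, only, known or untested is meant among the compounds shown, and "the series" means these compounds.

Measured compounds:
- compound 1 `O=C(COc1ccc(/C=C2\SC(=O)NC2=O)cc1)Nc1cccc([N+](=O)[O-])c1`: 58500 nM
- compound 2 `O=C(COc1ccc(/C=C2\SC(=O)NC2=O)cc1)Nc1ccc(Cl)cc1`: 51100 nM
- compound 3 `O=C(COc1ccc(/C=C2\SC(=O)NC2=O)cc1)Nc1c(F)cc(Br)cc1F`: 57300 nM

All three share one core and differ only in the aryl group on the amide-type nitrogen. In a functional assay on MCF7 cells (Homo sapiens) for inhibition (on this read-out lower numbers stand for stronger inhibition of growth and higher numbers for weaker inhibition of growth), compound 1 gives 58500 nM, the largest of the three numbers, but the steps to its neighbours are small: a 1.0-fold lower number from compound 1 to compound 3 (0.01 log units; within the scatter) and a 1.1-fold lower number from compound 1 to compound 2 (0.06 log units; within the scatter). The three compounds therefore cannot be told apart on this read-out.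

Compound 4 `O=C(COc1ccc(/C=C2\SC(=O)NC2=O)cc1)Nc1c(Cl)cccc1Cl` is the next member of the set. Relative to compound 1 it carries 2,6-dichlorophenyl in place of 3-nitrophenyl on an amide-type nitrogen. The steps already measured all concern exactly this kind of exchange of the aryl group on the amide-type nitrogen, and each of them stayed within the scatter: a 1.1-fold lower number from compound 1 to compound 2 (0.06 log units; within the scatter), a 1.0-fold lower number from compound 1 to compound 3 (0.01 log units; within the scatter) and a 1.1-fold higher number from compound 2 to compound 3 (0.05 log units; within the scatter). On that basis no step beyond the scatter is expected in this assay for compound 4 either, in neither direction, and the estimated step of a 1.1-fold lower number from compound 1 to compound 4 (0.03 log units; within the scatter) reflects this. Compound 4 is expected to give about 55000 nM, with a likely range from 28000 nM to 110000 nM.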

Compound 4, concentration for 50% growth inhibition: 61700 nM
For compound 4 the middle estimate is 1.1-fold (0.05 log units) below the measured one, and the stated range covers the measured number.
By their numbers in this assay, from the lowest: compounds 2, 3, 1 and 4 (each within the scatter of the next).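

In this assay, placing 2,6-dichlorophenyl on the amide-type nitrogen gives steps that all stay within the scatter (a 1.1-fold higher number from compound 1 to compound 4 (0.02 log units; within the scatter)), (a 1.1-fold higher number from compound 3 to compound 4 (0.03 log units; within the scatter)) and (a 1.2-fold higher number from compound 2 to compound 4 (0.08 log units; within the scatter)). The flat picture therefore now spans four aryl groups, and none of the four compounds goes against it: 3-nitrophenyl, 4-chlorophenyl, 4-bromo-2,6-difluorophenyl and 2,6-dichlorophenyl cannot be told apart on this read-out. Nothing available here explains why these exchanges leave the number in the same range.

Still open, as far as these compounds go, is whether a carboxylic acid or an amine on the phenyl ring, or a plain alkyl chain in place of that ring, would produce a step beyond the scatter. The compounds shown also leave open how changes to the shared core would affect growth inhibition, since all four keep it intact.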